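The source may hold more compounds than are shown below. What is called first, only, known or untested is meant among the compounds shown, and "the series" means these compounds.

Series notes, activation of Kir3.1/Kir3.2.

Measured so far:
compound 1 `Cc1cc(NC(=O)Cn2nnc(-c3ccccc3)n2)n(C2CCCCC2)n1` — 96 nM
compound 2 `Cc1cc(NC(=O)Cn2nnc(-c3cccnc3)n2)n(C2CCCCC2)n1` — 1930 nM
compound 3 `Cc1cc(NC(=O)Cn2nnc(-c3cccc(F)c3)n2)n(C2CCCCC2)n1` — 81 nM

In an assay on HEK293 cells for activation of Kir3.1/Kir3.2 (Homo sapiens), read by thallium flux (a lower number here means that less compound is needed, a higher number that more compound is needed for the effect), compound 3 gives the lowest of the three numbers; compound 1 stands nearest to it, at a 1.2-fold lower number from compound 1 to compound 3 (0.07 log units; within the scatter), and compound 2 furthest, at a 24-fold lower number from compound 2 to compound 3 (1.38 log units; beyond the scatter). The step under consideration leads to compound 4 `Cc1cc(NC(=O)Cn2nnc(-c3cccc(F)n3)n2)n(C2CCCCC2)n1`, which differs from compound 3 in one place: 6-fluoropyridin-2-yl in place of 3-fluorophenyl on an aromatic carbon.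

Among the measured compounds shown here, two measured steps bear on this. The change from a carbon-only ring to a ring with one hetero atom has been seen once, as a 20-fold higher number from compound 1 to compound 2 (1.30 log units; beyond the scatter), and the reverse as a 24-fold lower number from compound 2 to compound 3 (1.38 log units; beyond the scatter); the fluoro itself, as a 1.2-fold lower number from compound 1 to compound 3 (0.07 log units; within the scatter), changed nothing beyond the scatter. The ring nitrogen in compound 4 sits at a different position from that in compound 2, so the size carries over only loosely; a higher number in this assay is nonetheless expected for compound 4, estimated at a 9.9-fold higher number from compound 3 to compound 4 (0.99 log units; beyond the scatter). Compound 4 is therefore expected near 800 nM, within 200 nM to 4000 nM.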

Compound 4, half-maximal effective concentration: > 3000 nM
Compound 4 gave a limit, no number; the forecaster's own chance of this, stated with the estimate: 10%; middle value at least 3.7-fold (0.57 log units) away from the limit.
By their numbers in this assay, from the lowest: compounds 3 and 1 (each within the scatter of the next); then compound 2. At a limit, above all of these: compound 4.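

Compound 4 gives a limit, not a number, in this assay: the limit of > 3000 nM in this assay, at which 1 of the 4 values shown sits.

With the fluoro kept, a ring nitrogen in place of a ring carbon still gives a large step, an at least 37-fold higher number from compound 3 to compound 4 (1.56 log units; beyond the scatter), and the step from the plain phenyl is also large, an at least 31-fold higher number from compound 1 to compound 4 (1.49 log units; beyond the scatter), so a fluoro that stayed within the scatter on phenyl does not bring the nitrogen-containing ring back to the level of compounds 1 and 3. Against the other nitrogen-containing ring the result is only a floor, an at least 1.5-fold higher number from compound 2 to compound 4 (0.19 log units; that floor lies within the scatter), so compounds 2 and 4 cannot yet be told apart.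

Going by these compounds, how far compound 4 lies past its limit stays open. So does whether an unsubstituted pyridin-2-yl, or a methoxy or trifluoromethyl on the phenyl ring, would hold the number near that of compounds 1 and 3.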